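The source may hold more compounds than are shown below. What is called first, only, known or untested is meant among the compounds shown, and "the series" means these compounds.

Going by the values given here, in a functional assay on K562 cells (Homo sapiens) for antiproliferative activity, read by MTT assay, with a stated time of 72 h (a lower number here means a stronger inhibitor, a higher number a weaker inhibitor), two compounds sharing one core have numbers so far. Compound 1 (`COc1cc(C(=O)c2sc3ccccc3c2-c2ccc(F)cc2)cc(OC)c1OC`) gives 2100 nM, and compound 2 (`COc1cc(C(=O)c2sc3ccccc3c2-c2ccc(C)cc2)cc(OC)c1OC`) gives 3500 nM, which places compound 2 level with compound 1 within the usual scatter. Compound 3 (`COc1ccc(-c2c(C(=O)c3cc(OC)c(OC)c(OC)c3)sc3ccccc23)c(OC)c1`) has not yet been measured, and it swaps 2,4-dimethoxyphenyl in place of 4-methylphenyl on an aromatic carbon. Among the compounds with values here, only one measured step bears on this change, a 1.7-fold higher number from compound 1 to compound 2 (0.22 log units; within the scatter), which is methyl in place of fluoro on an aromatic carbon. Within the data shown here, that step alters the same aromatic group but is a smaller swap, and no measured compound carries a 2,4-dimethoxyphenyl group. A clear shift in either direction is therefore not expected, though the uncertainty is wide. The expected step is a 1.2-fold lower number from compound 2 to compound 3 (0.07 log units; within the scatter). Compound 3 is estimated at 3000 nM, with an expected range from 1000 nM to 9000 nM.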

Compound 3, half-maximal inhibitory concentration: 4100 nM
The estimate for compound 3 lay 1.4-fold (0.14 log units) below the measured number, and the stated range covers the measured number.
By their numbers in this assay, from the lowest: compounds 1, 2 and 3 (each within the scatter of the next).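

In this assay, 2,4-dimethoxyphenyl in place of 4-methylphenyl gives a 1.2-fold higher number from compound 2 to compound 3 (0.07 log units; within the scatter), and 2,4-dimethoxyphenyl in place of 4-fluorophenyl gives a 2.0-fold higher number from compound 1 to compound 3 (0.29 log units; within the scatter), so both steps lie within the scatter. Compounds 1 and 2 differed only in one small substituent on the phenyl ring, whereas compound 3 shows that this position, two ring bonds from the ring sulfur, can carry a phenyl group with two methoxy groups and no separation from either earlier compound in this assay. Nothing available explains this lack of separation.

The compounds shown leave open whether an amine, a hydroxyl or a carboxylic acid on this phenyl ring would give a step beyond the scatter. They also leave open whether a single methoxy group would behave as the two methoxy groups of compound 3 do.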